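The source may hold more compounds than are shown below. What is called first, only, known or untested is meant among the compounds shown, and "the series" means these compounds.

Measured in a functional assay on ZR-75-1 cells (Homo sapiens) for inhibition, read by sulforhodamine B assay; on this read-out lower numbers stand for stronger inhibition of growth and higher numbers for weaker inhibition of growth:
- Compound 1 `Cc1ccc2[nH]c(-c3ccc(-c4ccc(-c5cccc(Cl)c5)cc4)cc3)nc2c1`: 3450 nM
- Compound 2 `Cc1ccc2[nH]c(-c3ccc(-c4ccc(-c5ccccc5)cc4)cc3)nc2c1`: 27400 nM

Of these two compounds, compound 2 holds the higher number, at 27400 nM, and so shows the weaker inhibition of growth. Compound 3 `Cc1ccc2[nH]c(-c3ccc(-c4ccc(-c5ccc(F)cc5)cc4)cc3)nc2c1` departs from compound 2 in a single place: fluoro in place of hydrogen on an aromatic carbon. This puts fluoro in place of hydrogen on an aromatic carbon, turning phenyl into 4-fluorophenyl.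

For the measured compounds named here, only one measured step bears on this change: a 7.9-fold higher number from compound 1 to compound 2 (0.90 log units; beyond the scatter), with hydrogen in place of chloro on an aromatic carbon. Read in reverse, this step shows a halogen accompanying the lower number. It is only a loose guide, however, since compound 1 carries chloro rather than fluoro, and at a different place. Going by the values given here, no measured compound carries fluoro.

A step in the same direction is therefore expected, but a smaller one, perhaps hardly beyond the scatter. The expected change is a 2.0-fold lower number from compound 2 to compound 3 (0.29 log units; within the scatter). For compound 3 the estimated value is 14000 nM, with an expected range from 4500 nM to 38000 nM.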

Compound 3, concentration for 50% growth inhibition: 35000 nM
Estimate against measurement, compound 3: 2.5-fold (0.40 log units) below; low and high end bracket the measured number.
By their numbers in this assay, from the lowest: compound 1; then compounds 2 and 3 (each within the scatter of the next).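

In this assay, fluoro on this ring does not reproduce what chloro did in compound 1: a 1.3-fold higher number from compound 2 to compound 3 (0.11 log units; within the scatter) places the 4-fluorophenyl compound within the scatter of the phenyl compound, so this change gives no measurable separation. A halogen on this ring is thus not enough by itself to give the lower number, and compound 3 goes against any such reading, as a 10-fold higher number from compound 1 to compound 3 (1.01 log units; beyond the scatter) sets it well apart from the 3-chlorophenyl compound. Among these three compounds, only compound 1 stands apart, with compounds 2 and 3 lying within the scatter of each other, and nothing available here explains this difference between 3-chlorophenyl and 4-fluorophenyl.

The compounds shown leave open whether the gap between compound 1 and compound 3 follows the identity of the halogen or its place on the ring, a question that 4-chlorophenyl and 3-fluorophenyl would separate. They also leave open how this ring would respond to a group other than a halogen, such as methoxy, an amine or a carboxylic acid.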